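Swapping the Para Substituent: From Ester to Trifluoromethyl

The source may hold more compounds than are shown below. What is called first, only, known or untested is meant among the compounds shown, and "the series" means these compounds.

Measured compounds:
- compound 1, `COc1ccc(CO/N=C/c2c(C)nn(C)c2Oc2ccc(Cl)cc2)cc1`: 37%
- compound 2, `Cc1c(CO/N=C/c2c(-c3ccccc3)nn(-c3ccccc3)c2Oc2ccc(Cl)cc2)cccc1-c1ccccc1`: -17.5%
- compound 3, `CCOC(=O)c1ccc(CO/N=C/c2c(C)nn(C)c2Oc2ccc(Cl)cc2)cc1`: 33.9%

Three compounds share a core and differ in the groups hung from it. In a functional assay on MCF7 cells (Homo sapiens) for antiproliferative activity, tested at 1 uM (a lower number here means less inhibition, a higher number more inhibition at the concentration tested (going by the name of the read-out)), compound 3 gives 33.9%, the second highest of the three numbers. Its nearest neighbour is compound 1, which gives 37%, so the two stand within the scatter of each other. Compound 2 gives -17.5%, a number far lower than either of the other two, beyond the scatter.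

Compound 4, `Cc1nn(C)c(Oc2ccc(Cl)cc2)c1/C=N/OCc1ccc(C(F)(F)F)cc1`, has not yet been measured. It differs from compound 3 in one place: trifluoromethyl in place of ethoxycarbonyl on an aromatic carbon. Going by the values given here, the one measured step that bears on this is the change at the same place from compound 1 to compound 3, a number 3.1 percentage points lower from compound 1 to compound 3 (within the scatter), in which methoxy was exchanged for ethoxycarbonyl without any change beyond the scatter. That step suggests that the group sitting on this aromatic carbon, para to a large group, has little influence on the read-out, at least across the two groups tried so far.

On that basis compound 4 is expected to sit near compound 3, with a number 0.9 percentage points lower from compound 3 to compound 4 (within the scatter) as the estimated step. The estimate for compound 4 in this assay is 33%, with a range from 15% to 50%.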

Compound 4, a percentage reported as inhibition, at one concentration (the size of the read-out at that concentration, not a potency): 16.4%
Beside the measured number, compound 4's estimate is 16.6 percentage points above it, within the range that was stated.
By their numbers in this assay, from the lowest: compound 2; then compound 4; then compounds 3 and 1 (each within the scatter of the next).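

Trifluoromethyl in place of ethoxycarbonyl gives a number 17.5 percentage points lower from compound 3 to compound 4 (beyond the scatter) in this assay and trifluoromethyl in place of methoxy gives a number 20.6 percentage points lower from compound 1 to compound 4 (beyond the scatter) in the same read-out. Going by these compounds alone, this aromatic carbon is therefore not indifferent to what it carries: methoxy and ethoxycarbonyl stand within the scatter of each other, and trifluoromethyl is the first group here to shift the number beyond it. Methoxy and ethoxycarbonyl both contain oxygen and trifluoromethyl contains none, but three groups are too few to tell whether that difference matters, and nothing available here explains the drop.

From the compounds shown here alone, what stays open is whether the lower number belongs to trifluoromethyl alone or would also come with other groups at this place, such as a nitrile, a carboxylic acid, an amine or a single chlorine. Going by these compounds, it is also open whether the same exchange would give a step of similar size on a core carrying different groups elsewhere, since all of these comparisons rest on one shared core.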